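The compounds below may be only part of what the source reports. "The series", "measured", "known", "first", "only" and "open" are said of these compounds alone.

Compound 1 `CCCC[S+]([O-])c1sc2nc(-c3nccs3)cc(-c3cccc(CO)c3)c2c1N`: 4.3 nM
Compound 2 `CCCC[S+]([O-])c1sc2nc(-c3nccs3)cc(-c3ccc(COC(=O)CN(C)C)cc3)c2c1N`: 3.5 nM
Compound 3 `CCCC[S+]([O-])c1sc2nc(-c3nccs3)cc(-c3ccc(CNC(=O)NCC)cc3)c2c1N`: 2.1 nM

In an assay for inhibition of 15-hydroxyprostaglandin dehydrogenase [NAD(+)] (Homo sapiens), read by fluorescence, with a stated time of 15 min, in the presence of a further agent that is not named here (on this read-out higher numbers stand for weaker inhibition and lower numbers for stronger inhibition), compound 3 gives the lowest of the three numbers; against compound 2 its value lies within the scatter, while against compound 1 the two values differ beyond it. Compound 4 `CCCC[S+]([O-])c1sc2nc(-c3nccs3)cc(-c3ccc(C(=O)OC)cc3)c2c1N` carries methoxycarbonyl in place of ((ethylcarbamoyl)amino)methyl on an aromatic carbon. Among the compounds with values here, the one measured step that touches the same aromatic carbon, a 1.7-fold lower number from compound 2 to compound 3 (0.22 log units; within the scatter), was within the scatter, so changing the group on this ring has so far moved the number little. Within the data shown here, that step is the only guide; the present change removes both donors, which no measured pair covers. Compound 4 is therefore expected to stay close to compound 3, with a 1.9-fold higher number from compound 3 to compound 4 (0.28 log units; within the scatter) as the expected step. The estimate for compound 4 in this assay is 4 nM, with a range from 1.5 nM to 12 nM.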

Compound 4, half-maximal inhibitory concentration: 15.1 nM
Beside the measured number, compound 4's estimate is 3.8-fold (0.58 log units) below it, and the stated range ends below it.
By their numbers in this assay, from the lowest: compounds 3, 2 and 1 (each within the scatter of the next, the first and the last beyond it); then compound 4.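

In this assay, methoxycarbonyl on this aromatic carbon gives a number clearly higher than either larger group it replaces (a 7.2-fold higher number from compound 3 to compound 4 (0.86 log units; beyond the scatter); a 4.3-fold higher number from compound 2 to compound 4 (0.63 log units; beyond the scatter)), although those two groups lie within the scatter of each other. The step to compound 4 from the hydroxymethyl compound (a 3.5-fold higher number from compound 1 to compound 4 (0.55 log units; beyond the scatter)) runs the same way, but there the position on the ring changes too. No supporting data give a cause for this rise. Going by these compounds, what remains open is whether the ester itself or the loss of the methylene-linked chain drives the change, and how a carboxylic acid or a primary amide on this carbon would read.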